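The compounds below may be only part of what the source reports. "The series", "measured", "known", "first", "only" and "open" are said of these compounds alone.

Among the compounds with values here, in an ADME assay on microsomes from liver (Rattus norvegicus) for metabolic stability (a lower number here means that the compound disappears faster, a higher number that the compound lasts longer), compound 2 `CCC(/C=C1\OC(=O)NC1=O)(CC)c1ccc(-c2ccc3cccc(C(C)C)c3c2)[nH]c1=O` gives 1.88 h, the only actual number so far. Compound 1 `CCC(/C=C1\OC(=O)NC1=O)(CC)c1ccc(-c2ccc3cccc(F)c3c2)[nH]c1=O` is reported as > 3 h, which is a limit of the assay and not a number. Within the data shown here, the one measured step bearing on what follows is an at least 1.5-fold lower number from compound 1 to compound 2 (0.20 log units; that floor lies within the scatter), with isopropyl in place of fluoro on an aromatic carbon. Compound 3 `CCC(/C=C1\OC(=O)NC1=O)(CC)c1ccc(-c2ccc3cccc(C(F)(F)F)c3c2)[nH]c1=O` differs from compound 2 by trifluoromethyl in place of isopropyl on an aromatic carbon. Isopropyl leaves again, so the only guide is an at least 1.5-fold lower number from compound 1 to compound 2 (0.20 log units; that floor lies within the scatter), and a small rise in this assay is expected, probably not beyond the scatter. The expected step is a 1.4-fold higher number from compound 2 to compound 3 (0.14 log units; within the scatter). For compound 3 the estimate is 2.6 h, with an expected range of 1.5 h to 4.2 h.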

Compound 3, half-life: 1.09 h
Estimate against measurement, compound 3: 2.4-fold (0.38 log units) above; the measured number lies below the stated range.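

In this assay, putting trifluoromethyl in place of isopropyl gives a 1.7-fold lower number from compound 2 to compound 3 (0.24 log units; within the scatter), so these two groups cannot be told apart at this position. The change from fluoro to trifluoromethyl, however, gives an at least 2.7-fold lower number from compound 1 to compound 3 (0.43 log units; beyond the scatter), the first step at this position shown to lie beyond the scatter, whereas the floor of the step from fluoro to isopropyl stayed within it. The value of compound 1 is a limit of the assay and not a number, so the true size of this step stays unknown: the limit of > 3 h in this assay, at which 1 of the 3 values shown sits.

The data do not tell what about the fluoro group separates it from trifluoromethyl in this assay. As far as these compounds go, how a methoxy group, a nitrile or an amine at this same aromatic carbon would read also remains open.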